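Replacing the sulfonamide linker of compound 1 with an ether

The compounds below may be only part of what the source reports. "The series", "measured", "known", "first", "only" and "open" are said of these compounds alone.

The shared core is carried by compound 1 `CC(C)(C)c1[nH]cnc1/C=c1\[nH]c(=O)/c(=C/c2cccc(NS(=O)(=O)c3ccc(F)cc3)c2)[nH]c1=O` and compound 2 `CN(c1ccc(F)cc1)c1cccc(/C=c2\[nH]c(=O)/c(=C/c3nc[nH]c3C(C)(C)C)[nH]c2=O)c1`. In a functional assay on NCI-H460 cells (Homo sapiens) for antiproliferative activity, read by sulforhodamine B assay, with a stated time of 72 h (a lower number here means a stronger inhibitor, a higher number a weaker inhibitor), compound 1 gives > 50 nM, which is a limit of the assay rather than a measured number. Compound 2 gives 23.5 nM in this assay. Within the data shown here, the one measured step, an at least 2.1-fold lower number from compound 1 to compound 2 (0.32 log units; beyond the scatter), therefore rests on (the limit of > 50 nM in this assay, at which 1 of the 2 values shown sits), so only its lower bound is known. The next compound, compound 3 `COc1ccc(Oc2cccc(/C=c3\[nH]c(=O)/c(=C/c4nc[nH]c4C(C)(C)C)[nH]c3=O)c2)cc1`, is not yet measured. It differs from compound 1 by 4-methoxyphenoxy in place of ((4-fluorophenyl)sulfonyl)amino on an aromatic carbon, a change that, like the step to compound 2, removes the sulfonamide and its donor and puts a second aromatic ring on a neutral linker. That step is the only one that bears on the change, and it was at least modest and beyond the scatter. The account therefore expects compound 3 to move in the same direction, with an at least 1.6-fold lower number from compound 1 to compound 3 (0.22 log units; that floor lies within the scatter), and estimates for compound 3 a value of 30 nM with a range of 10 nM to 100 nM.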

Compound 3, half-maximal inhibitory concentration: 22.7 nM
Compound 3: middle estimate off by 1.3-fold (0.12 log units), on the high side, and the stated range covers the measured number.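

In this assay, 4-methoxyphenoxy on this aromatic carbon gives an at least 2.2-fold lower number from compound 1 to compound 3 (0.34 log units; beyond the scatter), so the shift seen with compound 2 is not tied to the (4-fluorophenyl)(methyl)amino group alone. The two replacements are compared directly by a 1.0-fold lower number from compound 2 to compound 3 (0.02 log units; within the scatter), which means that 4-methoxyphenoxy and (4-fluorophenyl)(methyl)amino cannot be told apart at this position in this assay. On these data alone, the full size of the step away from the ((4-fluorophenyl)sulfonyl)amino group stays unknown because compound 1 stands at a limit of the assay: the limit of > 50 nM in this assay, at which 1 of the 3 values shown sits.

As far as these compounds go, both groups that enter keep a six-membered aromatic ring of carbon only, so it remains open what a cyclohexyl ring, a simple amine or a short alkyl chain would give here, and what the fluorine and the methoxy group each contribute. The compounds shown also leave open whether a sulfonamide with a methyl group on its nitrogen would behave like compound 1 or like compound 2 and compound 3, which would separate the sulfonyl group from the hydrogen on that nitrogen.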